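The source may report more compounds than this note shows. Statements on the series, on what has been measured and on what is new or still open speak of the compounds shown alone.

Measured compounds:
compound 1 `Cc1nn(-c2cccc3cc(Cc4cccc(C(F)(F)F)c4)sc23)cc1C(=O)NCCO`: 5.2 nM
compound 2 `COCCNC(=O)c1c(C)nn(-c2cccc3cc(Cc4cccc(C(F)(F)F)c4)sc23)c1C`: 17 nM
compound 3 `Cc1nn(-c2cccc3cc(Cc4cccc(C(F)(F)F)c4)sc23)c(C)c1C(=O)NCCO`: 15 nM

All three numbers come from a functional assay on CHO cells for agonist activity at G-protein coupled receptor 52 (Homo sapiens), read by AlphaScreen and cAMP accumulation, with a stated time of 30 min; a higher number here means that more compound is needed for the effect, a lower number that less compound is needed. Compound 3 stands alongside compound 2, the two within the scatter of each other, and it lies beyond the scatter higher than compound 1. Going by the values given here, the single step that separates compound 3 from compound 1 reads a 2.9-fold higher number from compound 1 to compound 3 (0.46 log units; beyond the scatter), a methyl entering on the aromatic carbon of the core. The step from compound 2 reads a 1.1-fold lower number from compound 2 to compound 3 (0.05 log units; within the scatter), a methyl ether on the amide chain opened to the free alcohol.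

Compound 4 `Cc1c(C(=O)NCCO)c(CO)nn1-c1cccc2cc(Cc3cccc(C(F)(F)F)c3)sc12` differs from compound 3 by hydroxy in place of hydrogen on a saturated chain carbon bound to an aromatic carbon. Neither measured step repeats this change. a 2.9-fold higher number from compound 1 to compound 3 (0.46 log units; beyond the scatter) concerns the methyl that is here carried one atom further out into hydroxymethyl, and a 1.1-fold lower number from compound 2 to compound 3 (0.05 log units; within the scatter) shows that swapping methyl ether for hydroxy elsewhere in the molecule left the number within the scatter. Among the compounds with values here, no measured pair shows a hydroxy entering on a carbon attached to the core. With that, the expected step in this assay is small, no change at the digits printed from compound 3 to compound 4 (within the scatter), with no clear direction. Compound 4 is estimated at 15 nM in this assay, with a range from 5 nM to 45 nM.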

Compound 4, half-maximal effective concentration in the G-protein coupled receptor 52 assay: 146 nM
For compound 4 the middle estimate is 9.7-fold (0.99 log units) below the measured one; the whole stated range lies below it.
By their numbers in the G-protein coupled receptor 52 assay, from the lowest: compound 1; then compounds 3 and 2 (each within the scatter of the next); then compound 4.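

In the G-protein coupled receptor 52 assay, methyl to hydroxymethyl is the first change shown on this methyl, the one compound 1 already carries, since the earlier step of a 2.9-fold higher number from compound 1 to compound 3 (0.46 log units; beyond the scatter) concerned the other methyl; this change reads a 9.7-fold higher number from compound 3 to compound 4 (0.99 log units; beyond the scatter). A hydroxy is also not read alike everywhere in the molecule: on the amide chain, in the G-protein coupled receptor 52 assay, the step reads a 1.1-fold lower number from compound 2 to compound 3 (0.05 log units; within the scatter), within the scatter, whereas on this saturated chain carbon it lies beyond the scatter, and in a physicochemical assay for solubility, read by HPLC, at pH 6.8 (on this read-out lower numbers stand for lower solubility and higher numbers for higher solubility), where compound 3 gives 12 ug/mL and compound 4 gives 18 ug/mL, the same change reads a 1.5-fold higher number from compound 3 to compound 4 (0.18 log units; within the scatter), so no readable gain appears on that read-out. Nothing at hand accounts for the step at this position.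

Going by these compounds, whether the step belongs to the hydroxy itself stays open, as a methoxymethyl, an aminomethyl or a carboxylic acid in place of the hydroxymethyl could read near compound 4 or near compound 3. Going by these compounds alone, also open is whether a hydroxymethyl made from the other methyl, the one absent from compound 1, would give a step of similar size.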